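The source may hold more compounds than are shown below. What is called first, only, known or untested is meant among the compounds shown, and "the series" means these compounds.

Measured so far:
compound 1, `O=C(O)C1(Sc2ccnc3ccncc23)CCC1` — 1930 nM
compound 2, `O=C(O)C1(Sc2ccnc3ccc(O)cc23)CCC1` — > 10000 nM

In an assay on HEK293 cells for inhibition of solute carrier family 22 member 12 (Homo sapiens), read by scintillation counting, with a stated time of 12 min (on this read-out lower numbers stand for stronger inhibition and higher numbers for weaker inhibition), compound 1 gives 1930 nM. Compound 2 returns only a limit of the assay, > 10000 nM, so no number is known for it; this is the line (the limit of > 10000 nM in this assay, at which 1 of the 2 values shown sits), at which compound 2 sits. Of the two compounds shown, compound 2 is therefore the one whose inhibition the assay could not resolve, while compound 1 gives a measured value.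

Compound 3, `O=C(O)C1(Sc2ccnc3ccc(-c4ccccc4F)cc23)CCC1`, has not yet been measured. It differs from compound 2 by 2-fluorophenyl in place of hydroxy on an aromatic carbon. Compound 2 gives no number of its own. With compound 1 giving 1930 nM, the step into a 2-fluorophenyl group is expected to move the read-out well beyond the scatter, toward stronger inhibition. The step from compound 2 to compound 3 is estimated as an at least 12-fold lower number from compound 2 to compound 3 (1.09 log units; beyond the scatter). Compound 3 is expected to give about 800 nM in this assay, within a range of 150 nM to 5000 nM, pending the measurement.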

Compound 3, half-maximal inhibitory concentration: 333 nM
The estimate for compound 3 lay 2.4-fold (0.38 log units) above the measured number; the measured number falls inside the stated range.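

In this assay, for the compounds shown here, the exchange of hydroxy for 2-fluorophenyl on this aromatic carbon gives an at least 30-fold lower number from compound 2 to compound 3 (1.47 log units; beyond the scatter), the first step that can be read at this position. The earlier compounds shown here showed only that hydroxy here leaves inhibition unresolved, whereas compound 3 gives 333 nM and shows that this carbon, meta to a fused ring and para to a fused ring, can carry a group of 7 heavy atoms with one six-membered aromatic ring and still give a measured inhibition. Compound 2 has only a limit and no number of its own, so the full size of this step stays unknown: the limit of > 10000 nM in this assay, at which 1 of the 3 values shown sits.

The compounds shown do not separate the share of the aromatic ring from that of the fluorine, and a plain phenyl or a lone fluorine on this carbon would be needed to tell them apart. They also leave open how an amine, a carboxylic acid or a longer chain would read out in this place, and whether the fluorine would matter elsewhere on the phenyl ring.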